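From Carbamoyl to Hydroxycarbamoyl in a Cytotoxicity Assay

This account rests on a few compounds, and the source may have more. Where it says the series, first, only, none or still open, it means among the compounds named here.

Compound 1, `COC(=O)/C=C/[C@H]1C[C@@H](O)[C@@H](O)C1`: in an ADME assay on S2 cells (Drosophila melanogaster) for cytotoxicity, read by MTT assay (a higher number here means that more compound is needed for the effect, a lower number that less compound is needed), compound 1 gives > 350000 nM, a limit of the assay.
Compound 2, `NC(=O)/C=C/[C@H]1C[C@@H](O)[C@@H](O)C1`: in this assay compound 2 gives > 250000 nM, again a limit.

Both measured compounds share the diol-bearing core and differ only in the group on the carbonyl carbon, amino in place of methoxy. The step that the two limits leave unreadable from compound 1 to compound 2 therefore cannot be sized, since both ends are limits rather than numbers. Compound 2 stands at the limit of > 250000 nM in this assay, at which 1 of the 2 values shown sits, and the other value shown stands at the limit of > 350000 nM in this assay, at which 1 of the 2 values shown sits.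

Compound 3, `O=C(/C=C/[C@H]1C[C@@H](O)[C@@H](O)C1)NO`, carries the change (hydroxy in place of hydrogen on an amide-type nitrogen). Going by the values given here, no measured step bears on this change: the only step between measured compounds is unreadable, so no direction or size can be drawn from it. The expectation for this assay is a step from compound 2 to compound 3 of no size beyond the scatter, estimated as a number no higher from compound 2 to compound 3 (the limit leaves the size open). Compound 3 is thus expected to give about 250000 nM, with a range from 80000 nM to 800000 nM, most likely reported as another limit.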

Compound 3, half-maximal effective concentration: > 250000 nM
Compound 3: a limit, no number (the forecaster's own chance of this, stated with the estimate: 70%); the middle value sits exactly at the limit.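

In this assay compound 3 gives > 250000 nM, a limit and not a number. Going by these compounds alone, no step from compound 1 or compound 2 to compound 3 can be read. The compounds shown leave open the concentration at which compound 1, compound 2 or compound 3 would reach the half-maximal effect, and whether carbamoyl to hydroxycarbamoyl changes it.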